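The source may hold more compounds than are shown below. What is called first, only, known or untested is meant among the compounds shown, and "the series" means these compounds.

Compound 1 `O=C(O)CCCCCCCCCCCOc1ccc2c(=O)c(-c3ccc(O)cc3)coc2c1` gives 130 nM in an assay (Cricetulus griseus) for inhibition of aldehyde dehydrogenase, mitochondrial (Homo sapiens); a higher number here means a weaker inhibitor, a lower number a stronger inhibitor. Compound 2 `O=C(O)CCCCCCCCCCCCCCCOc1ccc2c(=O)c(-c3ccc(O)cc3)coc2c1`, which carries a longer chain, reaches only the limit of this assay, > 9000 nM. Compound 3 `CCCCCCCCCCCCOc1ccc2c(=O)c(-c3ccc(O)cc3)coc2c1`, which has the carboxy replaced by methyl, likewise sits at that limit, > 9000 nM. The two measured steps from compound 1 are both large: an at least 69-fold higher number from compound 1 to compound 2 (1.84 log units; beyond the scatter) and an at least 69-fold higher number from compound 1 to compound 3 (1.84 log units; beyond the scatter). Between the two weak compounds the step cannot be read, a step that the two limits leave unreadable from compound 2 to compound 3, because both values sit at the limit of > 9000 nM in this assay, at which 2 of the 3 values shown sit.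

Compound 4 `CCCCCCOc1ccc2c(=O)c(-c3ccc(O)cc3)coc2c1` differs from compound 3 by a shorter chain: hydrogen in place of hexyl on a saturated chain carbon, six bonds along the chain from an oxygen on an aromatic ring. Going by the values given here, no measured pair shows what shortening the chain without the carboxy does; the only readable steps concern the carboxy itself, and removing it cost compound 3 all measurable activity. Compound 4 keeps that loss while also dropping part of the chain, so no recovery is expected, and compound 4 is estimated to stay at or near the limit, giving an expected 12000 nM (range 2000 nM to 60000 nM). The expected step is therefore a step that the limit leaves unreadable from compound 3 to compound 4, which is not readable against a limit.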

Compound 4, half-maximal inhibitory concentration: 1500 nM
Estimate against measurement, compound 4: 8.0-fold (0.90 log units) above; measured number outside the range, below it.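

Shortening the chain that carries no carboxy brings measurable activity back in this assay, with an at least 6.0-fold lower number from compound 3 to compound 4 (0.77 log units; beyond the scatter), so on this side chain the carboxy is not required for activity. The long acid gives a similar picture, with an at least 6.0-fold lower number from compound 2 to compound 4 (0.77 log units; beyond the scatter), and both of these sizes are only minimum sizes because the starting values sit at a limit: the limit of > 9000 nM in this assay, at which 2 of the 4 values shown sit. Even so, the short plain chain does not match the long chain ending in carboxy, with a 12-fold higher number from compound 1 to compound 4 (1.06 log units; beyond the scatter).

The compounds shown leave open how activity changes with an octyl or decyl chain, which would lie in length between the chains of compound 4 and compound 3. They also leave open what a carboxylic acid at the end of a chain as short as hexyl would do.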